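The compounds below may be only part of what the source reports. "The series", "measured", "known", "first", "only" and "open" are said of these compounds alone.

Compound 1 `O=C(Nc1ccc(Oc2ccnc3[nH]ccc23)cc1)c1ccc(-c2ccc(F)cc2F)cn1`: > 10000 nM
Compound 2 `Cc1ccc(-c2ccnc(C(=O)Nc3ccc(Oc4ccnc5[nH]ccc45)cc3)c2)cc1`: > 10000 nM

Both compounds were tested in a functional assay on PC-3 cells (Homo sapiens) for cytotoxicity, read by MTT assay, with a stated time of 72 h (on this read-out higher numbers stand for weaker inhibition and lower numbers for stronger inhibition), and neither gave a number. Compound 2 stands at > 10000 nM, which is a limit of the assay and not a measured value. The same holds for compound 1, so the data so far amount to the limit of > 10000 nM in this assay, at which 2 of the 2 values shown sit. Compound 3 `O=C(Nc1ccc(Oc2ccnc3[nH]ccc23)cc1)c1cc(-c2ccccc2)ccn1` differs from compound 2 at one place, with hydrogen in place of methyl on an aromatic carbon, which turns 4-methylphenyl into phenyl: hydrogen in place of methyl on an aromatic carbon. Among the measured compounds shown here, no measured step shows what this change does in this assay, so no shift beyond the scatter is expected in either direction. The expected step is a number no higher from compound 2 to compound 3 (the limit leaves the size open). For compound 3 the estimate is 10000 nM, with an expected range from 4000 nM to 25000 nM, and the assay may well report only a limit again.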

Compound 3, half-maximal inhibitory concentration: 3270 nM
Compound 3: middle estimate off by 3.1-fold (0.49 log units), on the high side, outside the stated range (below it).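

The change from 4-methylphenyl to phenyl, on an aromatic carbon para to a large group, gives an at least 3.0-fold lower number from compound 2 to compound 3 (0.48 log units; beyond the scatter) in this assay, so this position does respond to what it carries, and removing the methyl brings a measurable number. Compound 2 gives > 10000 nM, which is a limit of the assay, so the step has a lower bound and no exact size. Compound 3 is the only compound shown with a measured number, and the other values stay at the limit: the limit of > 10000 nM in this assay, at which 2 of the 3 values shown sit.

As far as these compounds go, whether an amine, a hydroxyl or a carboxylic acid on the same carbon would move the number further in either direction remains open. From the compounds shown here alone, it is also open whether the same change would act alike with the two fluorines of compound 1, which differs from compound 3 in more than one place.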